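Compound 3: cyanomethyl in place of 2,6-difluorophenyl

The source may hold more compounds than are shown below. What is called first, only, known or untested is meant among the compounds shown, and "the series" means these compounds.

Measured so far:
Compound 1 `O=C(Nc1nc(-c2ccc(Cl)c(Cl)c2)cs1)C1CC1`: 3000 nM
Compound 2 `O=C(Nc1nc(-c2ccc(Cl)c(Cl)c2)cs1)c1c(F)cccc1F`: 5000 nM

In a physicochemical assay for solubility, measured as kinetic solubility, with a stated time of 1 h, at pH 7.4 (a lower number here means a less soluble compound, a higher number a more soluble compound), compound 2 gives 5000 nM, which lies within the scatter of compound 1. The account now turns to compound 3 `N#CCC(=O)Nc1nc(-c2ccc(Cl)c(Cl)c2)cs1`, which has not yet been measured. It differs from compound 2 by cyanomethyl in place of 2,6-difluorophenyl on a carbonyl carbon. Within the data shown here, only one measured step bears on this place, a 1.7-fold higher number from compound 1 to compound 2 (0.22 log units; within the scatter), where 2,6-difluorophenyl took the place of cyclopropyl. That exchange involved a different pair of groups, so it is only a loose guide. With that single step as the evidence, no change beyond the scatter is expected in this assay, and no direction is favoured. The estimated change is a 1.2-fold higher number from compound 2 to compound 3 (0.08 log units; within the scatter). Compound 3 is expected to give 6000 nM, with an estimated range of 2000 nM to 18000 nM.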

Compound 3, solubility: 57000 nM
The estimate for compound 3 lay 9.5-fold (0.98 log units) below the measured number, and the stated range ends below it.
By their numbers in this assay, from the lowest: compounds 1 and 2 (each within the scatter of the next); then compound 3.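

In this assay the group on the carbonyl carbon turns out to matter far beyond the scatter, which the exchange between cyclopropyl and 2,6-difluorophenyl had not shown. Cyanomethyl gives an 11-fold higher number from compound 2 to compound 3 (1.06 log units; beyond the scatter) and also a 19-fold higher number from compound 1 to compound 3 (1.28 log units; beyond the scatter), so the large change appears against both of the earlier groups, each of which contains a ring, while cyanomethyl has no ring and carries a nitrile. The material at hand offers no measurement that explains this rise.

The compounds shown leave open whether the nitrile itself or the absence of a ring goes with the higher number, as cyanomethyl brings both at once. A plain ethyl group and a phenyl ring carrying a nitrile on the same carbonyl carbon would bear on that question.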